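The source may report more compounds than this note shows. Statements on the series, on what has been measured and on what is new or still open speak of the compounds shown alone.

The shared core of compound 1 `O=[N+]([O-])c1ccccc1CNc1cccc2[nH]ncc12` carries a nitro-substituted benzyl amine. In an assay for inhibition of Indoleamine 2,3-dioxygenase 1 (Homo sapiens), with stated times of 10 min and 60 min (a lower number here means a stronger inhibitor, a higher number a weaker inhibitor), compound 1 gives "nd" (no result reported), so no number is known for it. Two relatives of the core do have results. Compound 2 `FC(F)(F)c1cccc(CNc2cc(C(F)(F)F)cc3[nH]ncc23)c1` reaches only the limit of this assay, > 100000 nM, which is the limit of > 100000 nM in this assay, at which 1 of the 3 values shown sits. Compound 3 `O=[N+]([O-])c1ccc(CNc2cc(C(F)(F)F)cc3[nH]ncc23)cc1`, with a nitro group on its benzyl ring, gives 61000 nM in this assay. Compound 4 `O=[N+]([O-])c1ccccc1CNc1cc(C(F)(F)F)cc2[nH]ncc12` differs from compound 1 by trifluoromethyl in place of hydrogen on an aromatic carbon. Within the data shown here, as compound 1 has no number, no step in this assay can be sized for it; compound 4 is expected to be a weak inhibitor. For compound 4 the estimate in this assay is 50000 nM, between 15000 nM and 200000 nM.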

Compound 4, half-maximal inhibitory concentration: 14000 nM
Estimate against measurement, compound 4: 3.6-fold (0.55 log units) above, and the stated range ends above it.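

Compound 1 has no number, so compound 4 cannot be set against it and no step can be read. On these data alone, what trifluoromethyl in place of hydrogen does to this inhibition stays open. Nothing shown accounts for the result of compound 4.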